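The source may hold more compounds than are shown below. What is called first, only, known or untested is meant among the compounds shown, and "the series" means these compounds.

Compound 1 `Cc1cccc(-n2nncc2CN2C(=O)C3(C(C#N)=C(N)Oc4c3c3nc5ccccc5nc3c3ccccc43)c3ccccc32)c1`: in an ADME assay on HUVEC cells (Homo sapiens) for antiproliferative activity, read by MTT assay, with a stated time of 48 h (a higher number here means a weaker inhibitor, a lower number a stronger inhibitor), compound 1 gives > 50000 nM, a limit of the assay rather than a number.
Compound 2 `N#CC1=C(N)Oc2c(c3nc4ccccc4nc3c3ccccc23)C12C(=O)N(Cc1cnnn1-c1cccc(Cl)c1)c1ccccc12`: in this assay compound 2 gives > 50000 nM, again a limit.

Compound 2 therefore stands at the limit of > 50000 nM in this assay, at which 2 of the 2 values shown sit; its true value is not known, only that it lies beyond that boundary. The change to compound 3 `COc1ccc(-n2nncc2CN2C(=O)C3(C(C#N)=C(N)Oc4c3c3nc5ccccc5nc3c3ccccc43)c3ccccc32)cc1` is 4-methoxyphenyl in place of 3-chlorophenyl on an aromatic nitrogen. For the measured compounds named here, the one measured step that bears on this position, a step that the two limits leave unreadable from compound 1 to compound 2, cannot be read, since both of its compounds sit at the same limit. There is thus no measured basis for expecting a step in either direction, and the most likely outcome is that compound 3 also returns a limit. Compound 3 is estimated at 70000 nM, in a range from 20000 nM to 300000 nM. The step this estimate implies, a step that the limit leaves unreadable from compound 2 to compound 3, is expected to be none beyond the scatter.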

Compound 3, half-maximal inhibitory concentration: > 50000 nM
Compound 3 was reported as a limit (the forecaster's own chance of this, stated with the estimate: 85%); the middle value lies beyond the limit too.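

Compound 1, compound 2 and compound 3 all return a limit of the assay rather than a number, so no step between them can be read: the limit of > 50000 nM in this assay, at which 3 of the 3 values shown sit.

The compounds shown leave open how strong each one truly is in this assay, and whether the group on the aromatic nitrogen matters at all.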